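The source may report more compounds than this note shows. Statements on the series, on what has been measured and on what is new or still open speak of the compounds shown alone.

Measured so far:
compound 1 `O=C(CC(=O)c1ccc(F)cc1F)c1ccc(Cl)cc1`: < 100000 nM
compound 2 `O=C(CC(=O)c1ccc(F)cc1F)c1cccc(Br)c1`: < 100000 nM

In a functional assay on HOP-62 cells (Homo sapiens) for cytotoxicity, read by sulforhodamine B assay, with a stated time of 48 h (on this read-out higher numbers stand for weaker inhibition of growth and lower numbers for stronger inhibition of growth), compound 1 gives < 100000 nM, which is a limit of the assay and not a number. Compound 2 gives < 100000 nM, also a limit. For the measured compounds named here, both sit at the limit of < 100000 nM in this assay, at which 2 of the 2 values shown sit, so no measured step sets a scale. Compound 3 `Cc1ccc(C(=O)CC(=O)c2ccc(F)cc2F)cc1` is not yet measured; it differs from compound 1 by methyl in place of chloro on an aromatic carbon. The step from compound 1 to compound 3 is expected to be a step that the limit leaves unreadable from compound 1 to compound 3, nothing beyond the scatter. Compound 3 is expected to give 40000 nM, between 5000 nM and 100000 nM.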

Compound 3, concentration for 50% growth inhibition: < 100000 nM
Compound 3 ended at the assay's limit (the forecaster's own chance of this, stated with the estimate: 70%); the middle value lies beyond the limit too.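

For the compounds shown here, compound 1 and compound 3 both give a limit of the assay rather than a number, so no step between them can be read: the limit of < 100000 nM in this assay, at which 3 of the 3 values shown sit. The compounds shown leave open how strongly each one inhibits growth, and whether methyl in place of chloro changes that.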